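A few compounds are considered here, and "the series" means these few. Any claim that something is new, unique, unknown or untested is made for them only; others in the source may bear on it.

Of the compounds shown here, two have been measured in a functional assay on T47D cells (Homo sapiens) for cytotoxicity, read by CCK-8 assay; on this read-out higher numbers stand for weaker inhibition and lower numbers for stronger inhibition. Compound 1 `Oc1ccc(-c2cc(-c3ccsc3)cc(-c3ccccc3O)n2)cc1` reaches only the limit of this assay, > 50000 nM. Going by the values given here, compound 2 `Oc1cccc(-c2cc(-c3ccco3)cc(-c3ccccc3O)n2)c1` gives 820 nM in this assay, the only number among the values shown. The other value shown, that of compound 1, is a limit (the limit of > 50000 nM in this assay, at which 1 of the 2 values shown sits). Compound 3 `Oc1ccc(-c2cc(-c3ccco3)cc(-c3ccccc3O)n2)cc1` has not yet been measured. It differs from compound 2 by 4-hydroxyphenyl in place of 3-hydroxyphenyl on an aromatic carbon. Compound 1 also carries a 4-hydroxyphenyl group and sits at > 50000 nM in this assay, which points toward weaker inhibition for compound 3, although compound 1 and compound 3 differ elsewhere too and no step between them is shown. The step expected in this assay is a 15-fold higher number from compound 2 to compound 3 (1.17 log units; beyond the scatter), beyond the usual scatter and toward weaker inhibition. The estimate for compound 3 in this assay is 12000 nM, between 2000 nM and 50000 nM, with a real chance that only a limit is reported.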

Compound 3, half-maximal inhibitory concentration: > 50000 nM
Compound 3: only a limit was reported; the forecaster's own chance of this, stated with the estimate: 35%; middle value at least 4.1-fold (0.61 log units) away from the limit.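

With the furan-2-yl group and the rest of the core held constant, placing 4-hydroxyphenyl instead of 3-hydroxyphenyl next to the ring nitrogen gives an at least 60-fold higher number from compound 2 to compound 3 (1.78 log units; beyond the scatter) in this assay. The two groups have the same atoms and the same counts of donors and acceptors, so this one pair ties the change in read-out to how the hydroxyphenyl group is joined, which compounds 1 and 2, differing in more than one place, could not do. The step from compound 1 to compound 3 cannot be read, and the value of compound 3 is a limit, not a number: the limit of > 50000 nM in this assay, at which 2 of the 3 values shown sit.

From the compounds shown here alone, whether furan-2-yl or thiophen-3-yl matters on the 4-hydroxyphenyl background therefore stays open. So does whether a 3-methoxyphenyl or 3-aminophenyl group in this place would stay near compound 2 at 820 nM.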